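Cytotoxicity notes on an ether-to-ester change in one series

A few compounds are considered here, and "the series" means these few. Any claim that something is new, unique, unknown or untested is made for them only; others in the source may bear on it.

Measured compounds:
compound 1 `CCC1(Cc2ccccc2)OS(=O)(=O)C=C1OCc1ccc(Cl)cc1` — in an ADME assay on HEL cells (Homo sapiens) for cytotoxicity, with a stated time of 3 days (on this read-out higher numbers stand for lower toxicity in this test and lower numbers for higher toxicity in this test), compound 1 gives > 200000 nM
compound 2 `CCC1(Cc2ccccc2)OS(=O)(=O)C=C1OCc1ccc(C(C)(C)C)cc1` — in this assay compound 2 gives 200000 nM

Compound 1 is known in this assay only as a limit, not as a number, as the limit of > 200000 nM in this assay, at which 1 of the 2 values shown sits, records. Compound 2 gives a number that sits at the same level as that limit. Within the data shown here, the single measured step, a number no higher from compound 1 to compound 2 (the limit leaves the size open), covers tert-butyl in place of chloro on an aromatic carbon, and its size cannot be read because one end of it is the limit of the limit of > 200000 nM in this assay, at which 1 of the 2 values shown sits. Both measured compounds therefore stand at the top of what this assay reports.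

The unmeasured compound 3 `CCC1(Cc2ccccc2)OS(=O)(=O)C=C1OC(=O)c1ccccc1` differs from compound 1 by benzoyl in place of 4-chlorobenzyl on an oxygen on an unsaturated carbon. Among the measured compounds shown here, no measured step covers this change, so there is nothing to size it against; the only information is that the two measured compounds both lie at or beyond the upper edge of the assay. On that basis compound 3 is expected to give 200000 nM in this assay, with a range from 100000 nM to 400000 nM. The expected step of a number no higher from compound 1 to compound 3 (the limit leaves the size open) is thus expected to be none beyond the scatter, most likely again a limit.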

Compound 3, half-maximal cytotoxic concentration: > 200000 nM
Compound 3 ended at the assay's limit; the forecaster's own chance of this, stated with the estimate: 60%; the middle value lies on the limit itself.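

No new step can be read between compound 1 and compound 3 in this assay, because each of the two is known only as a limit, not as a number: the limit of > 200000 nM in this assay, at which 2 of the 3 values shown sit.

The compounds shown leave open whether benzoyl in place of 4-chlorobenzyl on this oxygen shifts the half-maximal cytotoxic concentration at all, and in which direction.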